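Working notes on half-life in a shared-core series

The compounds below may be only part of what the source reports. "The series", "measured", "known", "first", "only" and "open" are said of these compounds alone.

Measured so far:
compound 1 `O=C(NCc1cccc(Br)c1)N1C(=O)c2ccccc2S1(=O)=O`, > 166 h
compound 2 `O=C(OCc1ccccc1)N1C(=O)c2ccccc2S1(=O)=O`, > 166 h
compound 3 `CC(NC(=O)N1C(=O)c2ccccc2S1(=O)=O)c1ccccc1`, > 166 h

In a physicochemical assay for pharmacokinetics (on this read-out lower numbers stand for a shorter-lived compound and higher numbers for a longer-lived compound), compound 1 gives > 166 h, which is a limit of the assay rather than a number. Compound 2 gives > 166 h, also a limit. Compound 3 gives > 166 h, also a limit. Compound 1 therefore stands at the limit of > 166 h in this assay, at which 3 of the 3 values shown sit, and no measured step separates any two of these compounds.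

The next compound is compound 4 `COc1ccccc1CNC(=O)N1C(=O)c2ccccc2S1(=O)=O`. It differs from compound 1 by 2-methoxyphenyl in place of 3-bromophenyl on a saturated chain carbon bound to an amide-type nitrogen. No step beyond the usual scatter is expected in this assay, in either direction. For compound 4 the estimated value is 200 h, spanning 100 h to 400 h, which is expected to mean a step that the limit leaves unreadable from compound 1 to compound 4.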

Compound 4, half-life: > 166 h
Compound 4 ended at the assay's limit; the forecaster's own chance of this, stated with the estimate: 80%; the middle value does not contradict the limit.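

In this assay compound 4 gives > 166 h as a limit of the assay. No step can be read from compound 1 to compound 4. The compounds shown leave open how far any true half-life lies past this limit.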